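The source may report more compounds than this note shows. Statements on the series, on what has been measured and on what is new or still open speak of the compounds shown alone.

Compound 1 `CC(C)=CC[C@@H](OC(=O)C1CCCO1)C1=CC(=O)c2c(O)ccc(O)c2C1=O` is the point of departure. In a functional assay on HeLa cells (Homo sapiens) for cytotoxicity, read by MTT assay (a higher number here means a weaker inhibitor, a lower number a stronger inhibitor), compound 1 gives 17000 nM, the lowest of the three numbers at hand, although each of its gaps to the other two lies within the scatter. Compound 2 `CC(C)=CC[C@@H](OCCO)C1=CC(=O)c2c(O)ccc(O)c2C1=O` carries a 2-hydroxyethyl in place of the (oxolan-2-yl)carbonyl on an oxygen on a saturated carbon and gives 18600 nM in this assay; compound 3 `CC(C)=CC[C@@H](OCC(C)O)C1=CC(=O)c2c(O)ccc(O)c2C1=O` carries a 2-hydroxypropyl at that oxygen and gives 24700 nM. The steps of a 1.1-fold higher number from compound 1 to compound 2 (0.04 log units; within the scatter) and a 1.5-fold higher number from compound 1 to compound 3 (0.16 log units; within the scatter) both stay within the scatter, as does a 1.3-fold higher number from compound 2 to compound 3 (0.12 log units; within the scatter). Compound 4 `CC(C)=CC[C@@H](OC(=O)C1CCCOC1)C1=CC(=O)c2c(O)ccc(O)c2C1=O` keeps the ester of compound 1 and alters only the ring on its carbonyl carbon: oxan-3-yl in place of oxolan-2-yl on a carbonyl carbon. Among the measured compounds shown here, no measured step covers this exact exchange; the nearest comparisons are those from compound 1 to compounds 2 and 3, in which the (oxolan-2-yl)carbonyl was removed altogether and the number moved only within the scatter. Because a 1.1-fold higher number from compound 1 to compound 2 (0.04 log units; within the scatter) and a 1.5-fold higher number from compound 1 to compound 3 (0.16 log units; within the scatter) stayed within the scatter when the whole group was replaced, swapping one saturated oxygen-containing ring for another inside that group is expected to produce no step beyond the scatter in this assay. Compound 4 is therefore expected to give about 18000 nM in this assay, between 9000 nM and 36000 nM, which amounts to the expected step of a 1.1-fold higher number from compound 1 to compound 4 (0.02 log units; within the scatter).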

Compound 4, half-maximal inhibitory concentration: 60500 nM
The estimate for compound 4 lay 3.4-fold (0.53 log units) below the measured number; the measured number lies above the stated range.
By their numbers in this assay, from the lowest: compounds 1, 2 and 3 (each within the scatter of the next); then compound 4.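

In this assay, among the compounds shown here, this position proved sensitive to the ring on the carbonyl carbon: oxan-3-yl in place of oxolan-2-yl, a six-membered for a five-membered non-aromatic ring with the same counts of hydrogen-bond donors and acceptors, gives a 3.6-fold higher number from compound 1 to compound 4 (0.55 log units; beyond the scatter), the first step beyond the scatter. For the compounds shown here, compound 4 also separates from the compounds carrying 2-hydroxyethyl and 2-hydroxypropyl on that oxygen, with a 3.3-fold higher number from compound 2 to compound 4 (0.51 log units; beyond the scatter) and a 2.4-fold higher number from compound 3 to compound 4 (0.39 log units; beyond the scatter), so the ester group as such does not set the number, and the exact ring on it matters more than the earlier compounds suggested. Nothing available accounts for this step.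

Oxolan-2-yl and oxan-3-yl differ in both ring size and the ring's point of attachment, so it stays open which of the two carries the step, a question that oxan-2-yl and oxolan-3-yl on the same carbonyl carbon could separate. Also open, going by these compounds, is where an amine-bearing ring such as piperidin-3-yl, or an open chain such as pentyl, would stand at this place in this assay.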